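The compounds below may be only part of what the source reports. "The series", "measured", "known", "first", "only" and "open" are said of these compounds alone.

Compound 1, with the structure `COc1ccccc1-n1cc(COc2c(/C=C\C(=O)O)ccc(OC)c2CC=C(C)C)nn1`, is one of a small set of close relatives that share a core and differ only in the aromatic group attached to a ring nitrogen. In a functional assay on PC-3 cells (Homo sapiens) for cytotoxicity, read by MTT assay, with a stated time of 24 h (a higher number here means a weaker inhibitor, a lower number a stronger inhibitor), compound 1 gives "not determined" (no result reported), so no number anchors it. Two relatives do carry numbers. Compound 2, `COc1ccc(/C=C\C(=O)O)c(OCc2cn(-c3cccc(C#N)c3)nn2)c1CC=C(C)C`, gives 45500 nM in this assay, and compound 3, `COc1ccc(/C=C\C(=O)O)c(OCc2cn(-c3ccc(CO)cc3)nn2)c1CC=C(C)C`, gives 28300 nM. Within the data shown here, the only step between measured compounds, a 1.6-fold lower number from compound 2 to compound 3 (0.21 log units; within the scatter), swaps one aromatic substituent for another and barely moves the read-out.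

Compound 4, `COc1ccc(/C=C\C(=O)O)c(OCc2cn(-c3ccccc3C(=O)N3CCC(O)C3)nn2)c1CC=C(C)C`, is compound 1 with one change: (3-hydroxypyrrolidin-1-yl)carbonyl in place of methoxy on an aromatic carbon. This is again a swap of the group on the aromatic ring that hangs from the ring nitrogen, the same kind of edit that separates compound 2 from compound 3. That single step was small, so the expectation is that the change from compound 1 to compound 4 also produces no shift in this assay beyond the scatter, though with compound 1 unmeasured the baseline itself must be borrowed from compound 2 and compound 3. On that basis compound 4 is expected to give about 32000 nM in this assay, most likely between 10000 nM and 100000 nM.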

Compound 4, half-maximal inhibitory concentration: 36200 nM
Compound 4: middle estimate off by 1.1-fold (0.05 log units), on the low side; the range from low to high includes it.
By their numbers in this assay, from the lowest: compounds 3, 4 and 2 (each within the scatter of the next).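

In this assay compound 1 stands at "not determined" (no result reported) and so the step from compound 1 to compound 4 cannot be read. The compounds shown leave open whether (3-hydroxypyrrolidin-1-yl)carbonyl in place of methoxy moves the read-out at all. No measured evidence here bears on the result for compound 4.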